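The source may hold more compounds than are shown below. What is called first, only, known or untested is meant among the compounds shown, and "the series" means these compounds.

Compound 2 `CCC(C)(C)/N=c1\c(O)c(O)\c1=N/Cc1c(C)cccc1Cl` gives 4400 nM in a functional assay for inhibition, with Rattus norvegicus as the target (on this read-out higher numbers stand for weaker inhibition and lower numbers for stronger inhibition), the highest of the two numbers shown. Compound 3 `CCC(C)(C)/N=c1\c(O)c(O)\c1=N/Cc1c(C)cc(C#N)cc1Cl` gives 160 nM, and the step of a 28-fold lower number from compound 2 to compound 3 (1.44 log units; beyond the scatter) came with cyano in place of hydrogen on an aromatic carbon. Compound 1 `CN(C)c1c(NCc2ccc(C#N)cc2)c(=O)c1=O` is reported only as a limit of this assay, > 30000 nM, which is the limit of > 30000 nM in this assay, at which 1 of the 3 values shown sits. Compound 4 `CCC(C)(C)/N=c1\c(O)c(O)\c1=N/Cc1c(C)cccc1C` differs from compound 2 by methyl in place of chloro on an aromatic carbon. No measured step exchanges a chloro for a methyl, and the single measured step concerns a cyano group, so nothing shown speaks directly to this change. Compound 4 is therefore expected to lie close to compound 2, the step of a 1.1-fold higher number from compound 2 to compound 4 (0.06 log units; within the scatter) expected to stay within the scatter. Compound 4 is estimated at 5000 nM, between 1500 nM and 16000 nM.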

Compound 4, half-maximal inhibitory concentration: 830 nM
Compound 4: middle estimate off by 6.0-fold (0.78 log units), on the high side, and the stated range ends above it.
By their numbers in this assay, from the lowest: compound 3; then compound 4; then compound 2. At a limit, above all of these: compound 1.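

In this assay, replacing chloro with methyl gives a 5.3-fold lower number from compound 2 to compound 4 (0.72 log units; beyond the scatter) and so shows that the aromatic carbon ortho to a large group also responds, although only one heavy atom is exchanged for another. Within the data shown here, until now, the only measured step concerned the cyano group at another place on the ring. Nothing shown accounts for this change.

The compounds shown leave open whether an ethyl or methoxy group at this place would lower the number further. They also leave open whether the step seen with cyano would hold alongside methyl.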